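Naphthyl Replacement at the Amine-Bound Chain Carbon

A few compounds are considered here, and "the series" means these few. Any claim that something is new, unique, unknown or untested is made for them only; others in the source may bear on it.

Compound 3 `O=S(=O)(NCCCNCc1ccc(Cl)c(C(F)(F)F)c1)c1cc(C(F)(F)F)cc(C(F)(F)F)c1` stands second highest of the three numbers in a functional assay on Capan-2 cells (Homo sapiens) for inhibition, read by MTT assay, with a stated time of 72 h; a higher number here means a weaker inhibitor of growth, a lower number a stronger inhibitor of growth; compound 3 gives 9100 nM. Its nearest neighbour is compound 2 `COc1ccc(CNCCCNS(=O)(=O)c2cc(C(F)(F)F)cc(C(F)(F)F)c2)cc1OC`, which in this assay gives 15000 nM, and the step of a 1.6-fold lower number from compound 2 to compound 3 (0.22 log units; within the scatter) lies within the scatter. Within the data shown here, compound 1 `O=S(=O)(NCCNCc1ccc(-c2ccccc2)cc1)c1cc(C(F)(F)F)cc(C(F)(F)F)c1` gives 2400 nM, a lower number, but it differs in the chain as well as the aryl group, so no single step joins it to compound 3. Compound 4 `O=S(=O)(NCCCNCc1cccc2ccccc12)c1cc(C(F)(F)F)cc(C(F)(F)F)c1` differs from compound 3 by naphthalen-1-yl in place of 4-chloro-3-(trifluoromethyl)phenyl on a saturated chain carbon bound to an amine nitrogen. Among the measured compounds shown here, the only single aryl swap on this chain was small, so compound 4 is expected to show a step of a 1.5-fold lower number from compound 3 to compound 4 (0.18 log units; within the scatter), a size like that of a 1.6-fold lower number from compound 2 to compound 3 (0.22 log units; within the scatter). Compound 4 is therefore estimated at 6000 nM, with a range from 2000 nM to 20000 nM.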

Compound 4, concentration for 50% growth inhibition: 2700 nM
The estimate for compound 4 lay 2.2-fold (0.35 log units) above the measured number, within the range that was stated.
By their numbers in this assay, from the lowest: compounds 1 and 4 (each within the scatter of the next); then compounds 3 and 2 (each within the scatter of the next).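

On this chain, the aryl group at this place can move the number beyond the scatter in this assay: naphthalen-1-yl gives a 3.4-fold lower number from compound 3 to compound 4 (0.53 log units; beyond the scatter) and a 5.6-fold lower number from compound 2 to compound 4 (0.74 log units; beyond the scatter) while the earlier swap between two single-ring groups stayed within it. The entering group carries two six-membered aromatic rings of carbon only, but these compounds cannot show whether the second ring is what matters. No evidence bearing on the reason for this step is available. Going by these compounds, whether naphthalen-2-yl would give a similar step stays open, as does whether naphthalen-1-yl would do so on the chain of compound 1.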